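Ring Size on the Amide: Cyclopropyl to Cyclopentyl

A few compounds are considered here, and "the series" means these few. Any claim that something is new, unique, unknown or untested is made for them only; others in the source may bear on it.

Compound 1 `CCCC(=O)Nc1ccn([C@@H]2CO[C@H](CO)O2)c(=O)n1`: 6600 nM
Compound 2 `O=C(Nc1ccn([C@@H]2CO[C@H](CO)O2)c(=O)n1)C1CC1`: 18700 nM

Both compounds were tested in a functional assay on A549 cells (Homo sapiens) for cytotoxicity, read by sulforhodamine B assay, with a stated time of 72 h; on this read-out higher numbers stand for weaker inhibition and lower numbers for stronger inhibition. Compound 2 stands at the highest of the two numbers shown, so it is the weaker of the pair; its nearest neighbour is compound 1, and the one measured step between them is a 2.8-fold higher number from compound 1 to compound 2 (0.45 log units; beyond the scatter), which came with cyclopropyl in place of propyl on the carbonyl carbon.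

Compound 3 `O=C(Nc1ccn([C@@H]2CO[C@H](CO)O2)c(=O)n1)C1CCCC1` has not been measured yet. It differs from compound 2 in one place: cyclopentyl in place of cyclopropyl on a carbonyl carbon. For the measured compounds named here, the only step that bears on this change is the one from propyl to cyclopropyl, a modest one beyond the scatter. It says that a three-carbon ring on this carbonyl carbon gave a higher number than a three-carbon chain, but it does not say how a larger ring would behave. A cautious reading is that the five-membered ring lands somewhere between the two measured compounds. The step expected is a 1.9-fold lower number from compound 2 to compound 3 (0.27 log units; within the scatter). In this assay compound 3 is therefore estimated at 10000 nM, within a range from 3500 nM to 30000 nM.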

Compound 3, half-maximal inhibitory concentration: 2970 nM
For compound 3 the middle estimate is 3.4-fold (0.53 log units) above the measured one; the whole stated range lies above it.
By their numbers in this assay, from the lowest: compound 3; then compound 1; then compound 2.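

Cyclopentyl on this carbonyl carbon changes the picture left by the first pair: a 6.3-fold lower number from compound 2 to compound 3 (0.80 log units; beyond the scatter) in this assay shows that the size of the ring at this place counts, not only whether a ring is there. A ring also does not always give the higher number, since the propyl chain of compound 1 now sits in the middle, with a 2.2-fold lower number from compound 1 to compound 3 (0.35 log units; beyond the scatter) running the opposite way from the earlier change of propyl to cyclopropyl. Both of its steps lie beyond the scatter, so compound 3 holds the lowest number of the three, which stands for the strongest inhibition among them.

From the compounds shown here alone, two rings are too few to establish a trend with ring size, so it stays open whether cyclohexyl on this carbonyl carbon would lower the number further or whether a longer chain could match cyclopentyl. What lies behind these steps also stays open, with no further data here that bear on them.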